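The source may report more compounds than this note shows. Statements on the series, on what has been measured and on what is new or still open speak of the compounds shown alone.

Measured so far:
compound 1, `COc1cccc(CCCC(=O)Nc2nc3ccccc3c(=O)s2)c1`: 389 nM
compound 2, `O=C(C/C=C/c1ccc(Cl)c(Cl)c1)Nc1nc2ccccc2c(=O)s1`: > 10000 nM
compound 3, `O=C(CCCc1ccccc1)Nc1nc2ccsc2c(=O)s1`: 206 nM

Three compounds share one assay, an in vitro assay on cells for inhibition of Amine oxidase [flavin-containing] B (Homo sapiens), read by fluorescence and Amplex Red, with stated times of 30 min and 45 min; a higher number here means a weaker inhibitor, a lower number a stronger inhibitor. In this assay compound 1 gives 389 nM. Within the data shown here, compound 3 gives 206 nM, so that of the two plain numbers the one for compound 1 is the higher, yet the gap between compound 1 and compound 3 is within the usual scatter, and neither can be called the stronger inhibitor. For compound 2 the assay reports only a limit, > 10000 nM; it is the limit of > 10000 nM in this assay, at which 1 of the 3 values shown sits, and not a number.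

The next compound to be measured is compound 4, `O=C(CCCc1cccc(Cl)c1)Nc1nc2ccccc2c(=O)s1`. Against compound 1 the single change is chloro in place of methoxy on an aromatic carbon. Among the measured compounds shown here, no pair of measured compounds differs in only this way, so no measured step can be pointed to. The expectation is a step in this assay no larger than the scatter, from compound 1 to compound 4, of a 1.3-fold lower number from compound 1 to compound 4 (0.11 log units; within the scatter). Compound 4 is therefore estimated at 300 nM, with a range from 110 nM to 850 nM.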

Compound 4, half-maximal inhibitory concentration: > 1000 nM
Compound 4 was reported as a limit; the forecaster's own chance of this, stated with the estimate: 5%; middle value at least 3.3-fold (0.52 log units) from the limit.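

In this assay, chloro does not serve as a like-for-like replacement for methoxy at this place on the aromatic ring: the change gives an at least 2.5-fold higher number from compound 1 to compound 4 (0.41 log units; beyond the scatter). Among these compounds, this is the first step in the set that compares compounds differing in one place, and it shows that the group on this carbon, meta to a large group, affects the read-out. Compound 4 gives only a limit and not a number: the limit of > 1000 nM in this assay, at which 1 of the 4 values shown sits.

The compounds shown leave open whether another group on this carbon, such as a hydroxyl, an amine or a fluoro, would give a number close to that of compound 1. They also leave open what the same swap would do on the core of compound 3, or on another carbon of this ring.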